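Ureido to piperazin-1-yl: working notes on compound 4

The source may report more compounds than this note shows. Statements on the series, on what has been measured and on what is new or still open speak of the compounds shown alone.

compound 1 `N#Cc1c(O)nc(SCc2nc3ccccc3[nH]2)nc1-c1ccccc1`: 6.57 nM
compound 2 `N#Cc1c(NNC(N)=S)nc(SCc2nc3ccccc3[nH]2)nc1-c1ccccc1`: 5.81 nM
compound 3 `N#Cc1c(NC(N)=O)nc(SCc2nc3ccccc3[nH]2)nc1-c1ccccc1`: 7.35 nM
compound 4 `N#Cc1c(-c2ccccc2)nc(SCc2nc3ccccc3[nH]2)nc1N1CCNCC1`: not yet measured

In a functional assay on NB1 cells (Homo sapiens) for cytotoxicity, read by MTT assay, with a stated time of 3 days (on this read-out lower numbers stand for stronger inhibition and higher numbers for weaker inhibition), compound 3 gives 7.35 nM, which cannot be separated from the other two values. The measured steps are a 1.1-fold higher number from compound 1 to compound 3 (0.05 log units; within the scatter) and a 1.3-fold higher number from compound 2 to compound 3 (0.10 log units; within the scatter).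

The change under study is piperazin-1-yl in place of ureido on an aromatic carbon, ortho to a cyano group (piperazin-1-yl in place of ureido on an aromatic carbon).

The closest evidence comes from the substituent swaps at this same place. Besides the two steps above, there is a 1.1-fold lower number from compound 1 to compound 2 (0.05 log units; within the scatter). For the measured compounds named here, all three stay within the scatter, so the series is flat across compounds 1, 2 and 3, and no measured compound goes against this. None of these substituents contains a ring, however, so piperazin-1-yl goes beyond what has been tested, and the range is kept wide.

An estimated 1.1-fold lower number from compound 3 to compound 4 (0.02 log units; within the scatter) is expected, meaning no step beyond the scatter. For compound 4 the expected value in this assay is 7 nM, with an estimated range of 3 nM to 16 nM.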

Compound 4, half-maximal inhibitory concentration: 6.75 nM
For compound 4 the middle estimate is 1.0-fold (0.02 log units) above the measured one, within the range that was stated.
By their numbers in this assay, from the lowest: compounds 2, 1, 4 and 3 (each within the scatter of the next).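

In this assay the piperazin-1-yl group, the only substituent at this position that carries a ring, gives a 1.1-fold lower number from compound 3 to compound 4 (0.04 log units; within the scatter) and a 1.2-fold higher number from compound 2 to compound 4 (0.07 log units; within the scatter) and also a 1.0-fold higher number from compound 1 to compound 4 (0.01 log units; within the scatter) as its steps. The flat picture of the series therefore now reaches a group with one six-membered non-aromatic ring with 2 hetero atoms on this aromatic carbon, ortho to a cyano group, and a larger group than ureido brings no step beyond the scatter. No independent data bear on why the number stays level across these substituents.

Open, on these data alone, is whether a ring without the second ring nitrogen, such as morpholin-4-yl, or a longer aminoalkyl chain or a carboxylic acid at this place would stay level too. Also open, as far as these compounds go, is whether the phenyl group or the benzimidazolylmethylthio part of the shared core tolerates change in the same way.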